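Amide aryl change on the pyrazole series

A few compounds are considered here, and "the series" means these few. Any claim that something is new, unique, unknown or untested is made for them only; others in the source may bear on it.

Measured compounds:
compound 1 `COc1cc(-c2nn(-c3cccc(NC(=O)Nc4cccc(C(F)(F)F)c4)c3)cc2-c2ccncc2)ccc1Cl` — a functional assay on COLO 205 cells (Homo sapiens) for inhibition, read by sulforhodamine B assay, with a stated time of 48 h; a higher number here means a weaker inhibitor of growth, a lower number a stronger inhibitor of growth: 1750 nM
compound 2 `COc1cc(-c2nn(-c3cccc(NC(=O)c4ccc(Cl)c(C(F)(F)F)c4)c3)cc2-c2ccncc2)ccc1Cl` — this assay: 23300 nM

For the measured compounds named here, compound 2 stands at the highest of the two numbers in this assay; its nearest neighbour is compound 1, and the only measured step, a 13-fold higher number from compound 1 to compound 2 (1.12 log units; beyond the scatter), separates them. Compound 3 `COc1cc(-c2nn(-c3cccc(NC(=O)c4ccccc4)c3)cc2-c2ccncc2)ccc1Cl` keeps the amide of compound 2 and changes only the aryl on the carbonyl carbon: phenyl in place of 4-chloro-3-(trifluoromethyl)phenyl on a carbonyl carbon. Going by the values given here, no measured step covers this kind of change; the one step known concerns the urea-to-amide exchange and does not bear on the aryl itself. The direction of the change from compound 2 to compound 3 therefore cannot be read from the data, and a step of either sign within a modest range is plausible. Compound 3 is expected to stay near compound 2, with an estimated step of a 1.3-fold higher number from compound 2 to compound 3 (0.11 log units; within the scatter), giving an estimate of 30000 nM with a range from 8000 nM to 100000 nM.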

Compound 3, concentration for total growth inhibition: 3230 nM
Compound 3: the middle estimate sits 9.3-fold (0.97 log units) above what was measured; measured number outside the range, below it.
By their numbers in this assay, from the lowest: compounds 1 and 3 (each within the scatter of the next); then compound 2.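

In this assay the aryl on the carbonyl carbon of the amide proves to be a sensitive place: phenyl in place of 4-chloro-3-(trifluoromethyl)phenyl gives a 7.2-fold lower number from compound 2 to compound 3 (0.86 log units; beyond the scatter), so the high number of compound 2 goes with that substituted aryl and not with the amide as such. The step of a 1.8-fold higher number from compound 1 to compound 3 (0.27 log units; within the scatter) places the plain phenyl amide and the urea of compound 1 within the scatter of each other. No measured evidence accounts for either step.

From the compounds shown here alone, whether the chlorine or the trifluoromethyl carries the step from compound 2 to compound 3 stays open, since the two groups leave together here. Also open, going by these compounds, is how this assay responds to a dimethylamino group or a carboxylic acid on the phenyl of compound 3.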